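Mirror-image pair: solubility expected to hold steady

The source may hold more compounds than are shown below. What is called first, only, known or untested is meant among the compounds shown, and "the series" means these compounds.

Measured compounds:
- compound 1, `CNCC(=O)Nc1ccc(-c2nc(CS(C)(=O)=O)cc([C@]34CCOC[C@H]3C4)n2)cc1`, 158 ug/mL
- compound 2, `CS(=O)(=O)Cc1cc(C2=CCOCC2)nc(-c2cccc(O)c2)n1`, 27 ug/mL
- compound 3, `CCNC(=O)Nc1ccc(-c2nccc(C3=CCOCC3)n2)cc1`, 24 ug/mL

Three compounds have been examined in a physicochemical assay for solubility, in phosphate buffer, measured as kinetic solubility, with a stated time of 1 h, at pH 7.4; a higher number here means a more soluble compound, a lower number a less soluble compound. Compound 1 gives 158 ug/mL, compound 2 gives 27 ug/mL, and compound 3 gives 24 ug/mL. Of the three numbers, compound 1 holds the highest; its nearest neighbour is compound 2, and the gap to it lies beyond the scatter, as does the wider gap to compound 3. Among the measured compounds shown here, no single-change step between two measured compounds is recorded, so the account rests on these three values alone.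

The next compound is compound 4, `CNCC(=O)Nc1ccc(-c2nc(CS(C)(=O)=O)cc([C@@]34CCOC[C@@H]3C4)n2)cc1`, which has not yet been measured in this assay. Its relation to compound 1 is as follows: the two compounds have the same atoms and bonds and differ only in configuration as drawn: 2 of 2 stereo elements differ (all stereocentres are inverted: mirror images); a stereocentre at a saturated ring carbon is drawn R in compound 1 and S in compound 4; a stereocentre at a saturated ring carbon is drawn S in compound 1 and R in compound 4. Nothing leaves and nothing enters; only the configuration as drawn changes.

For the measured compounds named here, with no measured step to lean on, the expectation is worded plainly: the step from compound 1 to compound 4 in this assay is expected to be none beyond the scatter, in neither direction, so no change at the digits printed from compound 1 to compound 4 (within the scatter) is the estimated step. On that basis compound 4 is estimated at 158 ug/mL, with a range from 80 ug/mL to 300 ug/mL.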

Compound 4, solubility: 167 ug/mL
Estimate against measurement, compound 4: 1.1-fold (0.02 log units) below; measured number inside the range.
By their numbers in this assay, from the lowest: compounds 3 and 2 (each within the scatter of the next); then compounds 1 and 4 (each within the scatter of the next).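

Among the compounds shown here, this is the first step that can be read in one place, since compounds 2 and 3 differ from compound 1 in more than one place and gave no such comparison. In this assay the record shows a 1.1-fold higher number from compound 1 to compound 4 (0.02 log units; within the scatter), so inverting both stereocentres at the saturated ring carbons leaves the reading within the scatter, and for this pair the drawn configuration does not separate the two numbers. The step can be tied to configuration alone, and to no change of group, because nothing else in the two structures differs: (the fact that compounds 1 and 4 differ only in the configuration as drawn).

The pair inverts both stereocentres together, so it does not tell how a compound with only one of them inverted, a diastereomer of compound 1, would read in this assay. It also leaves open whether the same insensitivity would hold if the saturated ring group gave way to another group, or if a carboxylic acid or a longer chain stood in place of the methylamino end of the amide.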